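Swapping the Sulfur-Linked Tetrazole for a Methylpiperazine

The compounds below may be only part of what the source reports. "The series", "measured", "known", "first", "only" and "open" are said of these compounds alone.

Two compounds share a core and differ only in the group attached to the chain that ends in the amide. Compound 1 `Cc1ccc2oc(SCC(=O)Nc3ccc(-c4nc(-c5ccccc5)c(-c5ccccc5)n4C)cc3)nc2c1` carries a benzoxazole on a sulfur; in a functional assay on MCF7 cells (Homo sapiens) for cytotoxicity, read by MTT assay, with a stated time of 24 h, tested at 6.4 ug/mL (a lower number here means a weaker effect, a higher number a stronger effect of the compound at the concentration tested), compound 1 gives 24.6%. Compound 2 `Cn1nnnc1SCC(=O)Nc1ccc(-c2nc(-c3ccccc3)c(-c3ccccc3)n2C)cc1` carries a tetrazole on that sulfur instead, and in this assay compound 2 gives 55.9%, the higher of the two numbers. For the measured compounds named here, the only measured step, a number 31.3 percentage points higher from compound 1 to compound 2 (beyond the scatter), shows that changing the group at this end of the chain can move the read-out a long way.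

Compound 3 `CN1CCN(CC(=O)Nc2ccc(-c3nc(-c4ccccc4)c(-c4ccccc4)n3C)cc2)CC1` goes further: 4-methylpiperazin-1-yl in place of (1-methyl-1H-tetrazol-5-yl)sulfanyl on a saturated chain carbon bound to a carbonyl carbon. The sulfur link and the aromatic ring both leave, and a non-aromatic ring enters. Going by the values given here, no measured pair shows this kind of change, so the step from compound 1 to compound 2 only tells that this position is sensitive, not which way a new group will turn. Among the compounds with values here, a step in either direction is therefore possible, and the expected value for compound 3 is set near the middle of the two known numbers, at 40%, within 15% to 70%, which means an expected step of a number 15.9 percentage points lower from compound 2 to compound 3 (beyond the scatter).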

Compound 3, a percentage reported as activity, at one concentration (the size of the read-out at that concentration, not a potency): 28.6%
Estimate against measurement, compound 3: 11.4 percentage points above, within the range that was stated.
By their numbers in this assay, from the lowest: compounds 1 and 3 (each within the scatter of the next); then compound 2.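

Within this assay, the step of a number 27.3 percentage points lower from compound 2 to compound 3 (beyond the scatter) shows that the higher read-out of compound 2 does not carry over to 4-methylpiperazin-1-yl, even though both groups have the same count of heavy atoms. The step of a number 4 percentage points higher from compound 1 to compound 3 (within the scatter) adds something the first pair could not show: two very different groups give read-outs that cannot be told apart, one a sulfur-linked aromatic system and the other a non-aromatic ring with no sulfur. A sulfur link with an aromatic ring is therefore not enough for a high read-out, as compound 1 shows, and among these three compounds only the (1-methyl-1H-tetrazol-5-yl)sulfanyl group stands apart, while no measurement here explains why.

Still open, from the compounds shown here alone, is whether the tetrazole needs its sulfur link, which a tetrazole joined to the chain through a nitrogen or an oxygen atom could test. It is also unclear how much the ring of compound 3 matters, and a morpholine ring or an open-chain dimethylamino group on the same saturated chain carbon would begin to separate the effect of the ring from that of its amine nitrogens.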